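Pyridyl isomers at one concentration: growth inhibition notes

The source may hold more compounds than are shown below. What is called first, only, known or untested is meant among the compounds shown, and "the series" means these compounds.

In a functional assay on HCT-116 cells (Homo sapiens) for inhibition, read by MTT assay, with a stated time of 24 h, tested at 2.5 uM (on this read-out higher numbers stand for more inhibition of growth at the one concentration tested and lower numbers for less inhibition of growth), the measured compounds give:
compound 1, `CS(=O)(=O)c1ccc(-c2cnc3[nH]cc(-c4nnc(-c5ccncc5)o4)c(=O)c3c2)cc1`: 2.64%
compound 2, `CS(=O)(=O)c1ccc(-c2cnc3[nH]cc(-c4nnc(-c5ccccc5)o4)c(=O)c3c2)cc1`: 0.53%
compound 3, `CS(=O)(=O)c1ccc(-c2cnc3[nH]cc(-c4nnc(-c5ccccn5)o4)c(=O)c3c2)cc1`: 5.37%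

Compound 1 stands second highest of the three numbers; its nearest neighbour is compound 2, a number 2.1 percentage points lower from compound 1 to compound 2 (within the scatter), and its furthest is compound 3, a number 2.7 percentage points higher from compound 1 to compound 3 (within the scatter). Compound 4 `CS(=O)(=O)c1ccc(-c2cnc3[nH]cc(-c4nnc(-c5cccnc5)o4)c(=O)c3c2)cc1` is not yet measured; it differs from compound 1 by pyridin-3-yl in place of pyridin-4-yl on an aromatic carbon. Within the data shown here, the steps that bear on this change are the other exchanges at the same aromatic carbon: a number 2.1 percentage points lower from compound 1 to compound 2 (within the scatter), a number 2.7 percentage points higher from compound 1 to compound 3 (within the scatter) and a number 4.8 percentage points higher from compound 2 to compound 3 (within the scatter), all within the scatter. No step beyond the scatter is therefore expected in this assay for compound 4; the expected step is a number 0.4 percentage points higher from compound 1 to compound 4 (within the scatter). Compound 4 is estimated at 3%, with a range of -5% to 12%.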

Compound 4, percent growth inhibition at one concentration: 4.32%
Compound 4: the middle estimate sits 1.3 percentage points below what was measured, within the range that was stated.
By their numbers in this assay, from the lowest: compounds 2, 1, 4 and 3 (each within the scatter of the next).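

In this assay, pyridin-3-yl completes the isomer set at this aromatic carbon: a number 1.7 percentage points higher from compound 1 to compound 4 (within the scatter), a number 1.1 percentage points lower from compound 3 to compound 4 (within the scatter) and a number 3.8 percentage points higher from compound 2 to compound 4 (within the scatter). Among pyridin-2-yl, pyridin-3-yl, pyridin-4-yl and phenyl, every exchange at this carbon now stays within the scatter, so the four compounds cannot be told apart at this one concentration. No measurement at hand bears on these numbers. From the compounds shown here alone, whether a carboxylic acid or an amine on this carbon would give a step beyond the scatter remains open.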